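Swapping a methylsulfanyl for a dichloropyridyl on the shared core

The compounds below may be only part of what the source reports. "The series", "measured", "known", "first", "only" and "open" are said of these compounds alone.

Compounds measured so far, in a functional assay on Jurkat cells for inhibition of nuclear factor NF-kappa-B complex (Homo sapiens); on this read-out lower numbers stand for stronger inhibition and higher numbers for weaker inhibition:
compound 1, `CCOC(=O)c1cnc(C(C)(C)C)nc1NN1C(=O)C=C(C)C1=O`: 1000 nM
compound 2, `CCOC(=O)c1cnc(SC)nc1NN1C(=O)C=C(C)C1=O`: 200 nM
compound 3, `CCOC(=O)c1cnc(-c2ccncc2)nc1NN1C(=O)C=C(C)C1=O`: 6000 nM

Compound 2 gives the lowest number of the three in this assay, with compound 1 closest (a 5.0-fold lower number from compound 1 to compound 2 (0.70 log units; beyond the scatter)) and compound 3 furthest (a 30-fold higher number from compound 2 to compound 3 (1.48 log units; beyond the scatter)). Compound 4, `CCOC(=O)c1cnc(-c2cc(Cl)nc(Cl)c2)nc1NN1C(=O)C=C(C)C1=O`, has not been measured yet. It differs from compound 2 in one place: 2,6-dichloropyridin-4-yl in place of methylsulfanyl on an aromatic carbon.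

For the measured compounds named here, the step that bears most directly on this change is the one from compound 2 to compound 3, where a plain pyridin-4-yl took the place of the same methylsulfanyl and gave a 30-fold higher number from compound 2 to compound 3 (1.48 log units; beyond the scatter). The step from compound 1 to compound 3 points the same way, a 6.0-fold higher number from compound 1 to compound 3 (0.78 log units; beyond the scatter), with a pyridin-4-yl again giving the higher number. Nothing measured shows what the two chlorine atoms add. On this basis compound 4 is expected to land well above compound 2 in this assay, a step of about a 20-fold higher number from compound 2 to compound 4 (1.30 log units; beyond the scatter). The estimate for compound 4 is 4000 nM, with a likely range from 1000 nM to 20000 nM.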

Compound 4, half-maximal inhibitory concentration: 2000 nM
Compound 4: the middle estimate sits 2.0-fold (0.30 log units) above what was measured; the range from low to high includes it.
By their numbers in this assay, from the lowest: compound 2; then compounds 1 and 4 (each within the scatter of the next); then compound 3.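

In this assay, placing two chlorine atoms on the aromatic group at this position changes the outcome: 2,6-dichloropyridin-4-yl in place of pyridin-4-yl gives a 3.0-fold lower number from compound 3 to compound 4 (0.48 log units; beyond the scatter) and so shows that the result depends on more than having a pyridine-type ring here. This gain is only partial, as the methylsulfanyl group remains clearly ahead with a 10-fold higher number from compound 2 to compound 4 (1.00 log units; beyond the scatter) and the comparison with tert-butyl gives a 2.0-fold higher number from compound 1 to compound 4 (0.30 log units; within the scatter) and so does not separate the two groups. No measurement available here explains why the chlorine atoms have this effect.

Going by these compounds, it remains open whether a single chlorine atom would do as much as two, or whether methyl groups in their place would do the same. Also open, on these data alone, is whether an amine or an ethylsulfanyl group at this position would give a lower number than compound 2 at 200 nM.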